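This account rests on a few compounds, and the source may have more. Where it says the series, first, only, none or still open, it means among the compounds named here.

In a toxicity assay on THP-1 cells (Homo sapiens) for inhibition (a higher number here means that more compound is tolerated, a lower number that less compound is tolerated), compound 1 (`COc1ccc(-c2cnc(NC(=O)CCc3ccccc3)n2C)cc1`) gives > 100000 nM, a limit of the assay. Compound 2 (`COc1ccc(-c2cnc(NC(=O)c3cccc(F)c3)n2C)cc1`) gives > 100000 nM, also a limit and not a number. Among the measured compounds shown here, the only measured step is a step that the two limits leave unreadable from compound 1 to compound 2, so it offers no size to carry forward, and the series so far stands at the limit of > 100000 nM in this assay, at which 2 of the 2 values shown sit. Compound 3 (`COc1ccc(-c2cnc(NC(=O)c3cccc(OC)c3)n2C)cc1`) differs from compound 2 by methoxy in place of fluoro on an aromatic carbon. In this assay the expected step, a number no higher from compound 2 to compound 3 (the limit leaves the size open), is none beyond the scatter, with no direction favoured. For compound 3 the estimate is 100000 nM, expected to fall between 50000 nM and 200000 nM.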

Compound 3, half-maximal cytotoxic concentration: > 100000 nM
Compound 3 gave a limit, no number; the forecaster's own chance of this, stated with the estimate: 85%; the middle value sits exactly at the limit.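

Among the compounds shown here, compound 1, compound 2 and compound 3 all sit at a limit of this assay, not at a number, so no step among them can be read. The compounds shown leave open whether any change on the carbonyl carbon or the aromatic ring alters tolerance: the limit of > 100000 nM in this assay, at which 3 of the 3 values shown sit.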